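The source may hold more compounds than are shown below. What is called first, only, known or untested is meant among the compounds shown, and "the series" means these compounds.

Measured in a functional assay on JeKo-1 cells (Homo sapiens) for inhibition, read by luminescence and CellTiter-Glo, with a stated time of 72 h; on this read-out lower numbers stand for stronger inhibition and higher numbers for weaker inhibition:
Compound 1 `C/C=C/C(=O)N1CCCC(n2nc(-c3ccc(Oc4ccccc4)cc3)cc2C(=O)OCC)C1`: 26500 nM
Compound 2 `C/C=C/C(=O)N1CCCC(n2nc(-c3ccc(Oc4ccccc4)cc3)cc2C(=O)O)C1`: > 60000 nM

Compound 2 gives > 60000 nM, which is a limit and not a number. Compound 3 `C/C=C/C(=O)N1CCCC(n2nc(-c3ccc(Oc4ccccc4)cc3)cc2CO)C1` differs from it by one change: hydroxymethyl in place of carboxy on an aromatic carbon. Among the measured compounds shown here, only one measured step bears on this group, hydrogen in place of ethyl, and it gave an at least 2.2-fold higher number from compound 1 to compound 2 (0.35 log units; beyond the scatter). Compound 3 also lacks the carboxy group, so a result closer to compound 1 at 26500 nM is expected. The expected step is an at least 1.7-fold lower number from compound 2 to compound 3 (0.23 log units; that floor lies within the scatter), though it is uncertain. For compound 3 the estimate is 35000 nM, with an expected range of 14000 nM to 80000 nM.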

Compound 3, half-maximal inhibitory concentration: > 60000 nM
Compound 3 was reported as a limit; the forecaster's own chance of this, stated with the estimate: 40%; at least 1.7-fold (0.23 log units) between middle value and limit.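

In this assay, hydroxymethyl in place of ethoxycarbonyl on this aromatic carbon gives an at least 2.2-fold higher number from compound 1 to compound 3 (0.35 log units; beyond the scatter). The weaker inhibition seen with carboxy at this position is therefore not unique to carboxy, since hydroxymethyl also gives it. Whether carboxy and hydroxymethyl differ from each other cannot be read, because compound 2 and compound 3 both stop at the same limit rather than at a number: the limit of > 60000 nM in this assay, at which 2 of the 3 values shown sit.

As far as these compounds go, it remains open whether an amide or a longer ester chain at this position would match or go beyond compound 1 at 26500 nM.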